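The source may hold more compounds than are shown below. What is called first, only, known or untested is meant among the compounds shown, and "the series" means these compounds.

In a functional assay on A549 cells (Homo sapiens) for antiproliferative activity, read by MTT assay, with a stated time of 48 h (a higher number here means a weaker inhibitor, a lower number a stronger inhibitor), compound 1 `Cn1c(N)c(-c2nc3ccccc3[nH]2)c2nc(C#N)c(C#N)nc21` gives > 50000 nM, which is a limit of the assay and not a number. Compound 2 `CN1CCN(CCn2c(N)c(-c3nc4ccccc4[nH]3)c3nc(C#N)c(C#N)nc32)CC1` gives 40500 nM, and compound 3 `CCCn1c(N)c(-c2nc3ccccc3[nH]2)c2nc(C#N)c(C#N)nc21` gives 1970 nM, the lowest number of the three. Compound 4 `CN(C)CCCn1c(N)c(-c2nc3ccccc3[nH]2)c2nc(C#N)c(C#N)nc21` has dimethylamino in place of hydrogen on a saturated chain carbon, three bonds along the chain from an aromatic nitrogen, so propyl becomes 3-(dimethylamino)propyl. Plain ethyl gave a large gain, an at least 25-fold lower number from compound 1 to compound 3 (1.40 log units; beyond the scatter). The 4-methylpiperazin-1-yl chain gave little, an at least 1.2-fold lower number from compound 1 to compound 2 (0.09 log units; that floor lies within the scatter), and swapping it for methyl gave a 21-fold lower number from compound 2 to compound 3 (1.31 log units; beyond the scatter). A partial loss in this assay therefore seems likely, with an expected step of a 4.1-fold higher number from compound 3 to compound 4 (0.61 log units; beyond the scatter). The estimate for compound 4 is 8000 nM, with an expected range of 2000 nM to 35000 nM.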

Compound 4, half-maximal inhibitory concentration: 10400 nM
Compound 4: the middle estimate sits 1.3-fold (0.11 log units) below what was measured, and the stated range covers the measured number.
By their numbers in this assay, from the lowest: compound 3; then compound 4; then compound 2. At a limit, above all of these: compound 1.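

Putting dimethylamino on the chain, three bonds along from an aromatic nitrogen, gives up part of the activity of the plain propyl chain (a 5.3-fold higher number from compound 3 to compound 4 (0.72 log units; beyond the scatter)). Still, the choice of amine matters, as this chain does better than the 4-methylpiperazin-1-yl chain (a 3.9-fold lower number from compound 2 to compound 4 (0.59 log units; beyond the scatter)). It also keeps a gain over the methyl of compound 1 (an at least 4.8-fold lower number from compound 1 to compound 4 (0.68 log units; beyond the scatter)), though that step rests on a limit of the assay and not a number: (the limit of > 50000 nM in this assay, at which 1 of the 4 values shown sits). Still open, from the compounds shown here alone, is how a hydroxyl group at the same chain carbon would compare. So is whether a longer chain, such as butyl, would go lower than the propyl chain of compound 3.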